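The source may report more compounds than this note shows. Statements on the series, on what has been measured and on what is new or still open speak of the compounds shown alone.

Working notes on the benzoxazole-sulfonamide pair and the proposed third member.

Compound 1 `O=S(=O)(Nc1ccc(-c2nc3ccccc3o2)cc1)c1ccc(Cl)s1` has been run in an ADME assay on HEK293 cells (Homo sapiens) for cytotoxicity, read by resazurin assay, with a stated time of 48 h; on this read-out lower numbers stand for higher toxicity in this test and higher numbers for lower toxicity in this test. In this assay compound 1 returns > 100000 nM, which is a limit of the assay rather than a number. Within the data shown here, compound 2 `O=S(=O)(Nc1ccc2oc(-c3ccccc3)nc2c1)c1ccc(O)cc1` is the only other measured member. In this assay compound 2 likewise returns > 100000 nM, again a limit and not a number. Where compound 1 stands is therefore fixed only as the limit of > 100000 nM in this assay, at which 2 of the 2 values shown sit; no numerical toxicity has been resolved for either measured compound, and no step between measured compounds can be stated.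

Compound 3 `O=S(=O)(Nc1ccc(-c2nc3ccccc3o2)cc1)c1ccc(F)cc1` is the next compound to be measured in this assay. It differs from compound 1 by 4-fluorophenyl in place of 5-chlorothiophen-2-yl on a sulfonyl sulfur.

With both measured values sitting at the same limit, no direction can be read from the pair. The expectation for the step is none beyond the scatter: compound 3 is estimated to remain at or close to the same limit, with a number no higher from compound 1 to compound 3 (the limit leaves the size open) as the expected step. Compound 3 is thus estimated at 100000 nM in this assay, within 30000 nM to 300000 nM, and most likely reported again only as a limit.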

Compound 3, half-maximal cytotoxic concentration: > 100000 nM
Compound 3: only a limit was reported; the forecaster's own chance of this, stated with the estimate: 80%; the middle value lies on the limit itself.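

In this assay compound 3 gives > 100000 nM as a limit and not a number. Among these compounds, no step from compound 1 to compound 3 can be read, since both sit at one limit: the limit of > 100000 nM in this assay, at which 3 of the 3 values shown sit.

The compounds shown leave open how 4-fluorophenyl and 5-chlorothiophen-2-yl on the sulfonyl sulfur would compare once a numerical half-maximal cytotoxic concentration is resolved.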